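Working notes: compounds 1 to 4, cytotoxicity series

The compounds below may be only part of what the source reports. "The series", "measured", "known", "first", "only" and "open" are said of these compounds alone.

Measured so far:
- compound 1 `Cc1ccc(/C=C2\CCC/C(=C\c3cccc([N+](=O)[O-])c3)C2=O)cc1`: in a functional assay on CCRF-CEM cells (Homo sapiens) for cytotoxicity, with a stated time of 72 h (on this read-out lower numbers stand for stronger inhibition and higher numbers for weaker inhibition), compound 1 gives 10100 nM
- compound 2 `O=C1/C(=C/c2ccc(F)cc2)CCC/C1=C\c1cccc([N+](=O)[O-])c1`: in this assay compound 2 gives 5050 nM
- compound 3 `CN(C)c1ccc(/C=C2\CCC/C(=C\c3cccc([N+](=O)[O-])c3)C2=O)cc1`: in this assay compound 3 gives 11700 nM

Compound 3 carries the highest of the three numbers. Against compound 1 the gap is a 1.2-fold higher number from compound 1 to compound 3 (0.06 log units; within the scatter), so the two are indistinguishable here; against compound 2 it is a 2.3-fold higher number from compound 2 to compound 3 (0.36 log units; beyond the scatter), a modest separation. The shared core is unchanged across the set and only the group on the aromatic carbon varies.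

The next compound, compound 4 `O=C1/C(=C/c2ccccc2)CCC/C1=C\c1cccc([N+](=O)[O-])c1`, takes that same position one step further: hydrogen in place of dimethylamino on an aromatic carbon.

For the measured compounds named here, two measured steps bear on this change, both of which swap the group on that aromatic carbon and end at compound 3: a 1.2-fold higher number from compound 1 to compound 3 (0.06 log units; within the scatter) and a 2.3-fold higher number from compound 2 to compound 3 (0.36 log units; beyond the scatter). The first is within the scatter, the second only modestly beyond it, and a 2.0-fold lower number from compound 1 to compound 2 (0.30 log units; within the scatter) is likewise within the scatter. Swaps at this position have therefore moved this assay little. For compound 4 the expected step is a 1.5-fold lower number from compound 3 to compound 4 (0.17 log units; within the scatter), that is, nothing reliably beyond the scatter, with a slight lean toward a lower number in line with compound 2.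

The estimate for compound 4 in this assay is 8000 nM, expected to fall between 4000 nM and 16000 nM.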

Compound 4, half-maximal inhibitory concentration: 2290 nM
Compound 4: the middle estimate sits 3.5-fold (0.54 log units) above what was measured, outside the stated range (below it).
By their numbers in this assay, from the lowest: compound 4; then compounds 2, 1 and 3 (each within the scatter of the next, the first and the last beyond it).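

In this assay this position turns out to respond, but only when the group is removed altogether: with hydrogen on this aromatic carbon, all three steps lie beyond the scatter (a 5.1-fold lower number from compound 3 to compound 4 (0.71 log units; beyond the scatter); a 2.2-fold lower number from compound 2 to compound 4 (0.34 log units; beyond the scatter); a 4.4-fold lower number from compound 1 to compound 4 (0.64 log units; beyond the scatter)). For the compounds shown here, the earlier swaps only exchanged one group for another among methyl, fluoro and dimethylamino, and of those only the step between the fluoro and dimethylamino compounds cleared the scatter, so the position looked nearly indifferent. Compound 4 now has the lowest number of the four, and none of compounds 1, 2 or 3 goes against the reading that, within this small set, each of the three groups gives a higher number than hydrogen.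

The data give no measured account of why hydrogen stands apart from the three groups. On these data alone, it remains open whether a chloro, a methoxy or a carboxylic acid on this carbon would stay with hydrogen or fall in with the other three, and whether the same gap would hold if the nitro group of the shared core were replaced, for instance by an amine.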